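The source may hold more compounds than are shown below. What is called first, only, known or untested is meant among the compounds shown, and "the series" means these compounds.

Measured compounds:
- Compound 1, `CC/N=C(/NC#N)NCCCn1nc(-c2ccccc2)ccc1=O`, gives 78.3 mg/kg in a functional assay on the whole organism (stomach) with Rattus norvegicus as the target; a lower number here means that less compound is needed, a higher number that more compound is needed for the effect.
- Compound 2, `C/N=C(\S)NCCCCn1nc(-c2ccccc2)ccc1=O`, gives 28.9 mg/kg in this assay.

Compound 2 stands at the lowest of the two numbers; its nearest neighbour is compound 1, and the step between them is a 2.7-fold lower number from compound 1 to compound 2 (0.43 log units; beyond the scatter). Compound 3, `CN(C)/C(=N/CCCCn1nc(-c2ccccc2)ccc1=O)NC#N`, has not yet been measured. It differs from compound 2 as follows: a group of 8 heavy atoms (4 carbon, 4 nitrogen; no ring) in place of a group of 5 heavy atoms (2 carbon, 2 nitrogen, 1 sulfur; no ring), on a saturated chain carbon, four bonds along the chain from an aromatic nitrogen. Within the data shown here, the only measured step that bears on this change is the one from compound 1 to compound 2, in which a thiourea-type group replaced a cyanoguanidine-type group and the number fell by a modest, beyond-the-scatter amount. The change from compound 2 to compound 3 runs the other way, bringing a cyanoguanidine-type group back in, so a modest rise in the number is expected in this assay, roughly a 2.1-fold higher number from compound 2 to compound 3 (0.32 log units; beyond the scatter). Compound 3 is therefore estimated at 60 mg/kg, with a range from 25 mg/kg to 140 mg/kg.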

Compound 3, dose for half-maximal effect: 30.3 mg/kg
The estimate for compound 3 lay 2.0-fold (0.30 log units) above the measured number; the range from low to high includes it.
By their numbers in this assay, from the lowest: compounds 2 and 3 (each within the scatter of the next); then compound 1.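

On a saturated chain carbon, four bonds along the chain from an aromatic nitrogen, the group with 2 hydrogen-bond donors and 1 hydrogen-bond acceptor gives way to the group with 1 hydrogen-bond donor and 2 hydrogen-bond acceptors, and this assay shows a 1.0-fold higher number from compound 2 to compound 3 (0.02 log units; within the scatter). This position therefore tolerates the larger group of 8 heavy atoms in place of the group of 5 heavy atoms, so the earlier step, a 2.7-fold lower number from compound 1 to compound 2 (0.43 log units; beyond the scatter), cannot be read as a general effect of exchanging these two kinds of group. The data offer no measured explanation for this result.

From the compounds shown here alone, whether a urea or a primary amine at this position would also stay within the scatter of compound 2 remains open. So does the effect of a longer chain carrying the group of 8 heavy atoms.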